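The source may report more compounds than this note shows. Statements on the series, on what has been measured and on what is new or still open speak of the compounds shown alone.

Of the compounds shown here, three of one shared core have been measured in an ADME assay on the whole organism (plasma) for pharmacokinetics, with Rattus norvegicus as the target, with a stated time of 6 h, at a dose of 10 mg/kg by the oral route; on this read-out lower numbers stand for lower exposure and higher numbers for higher exposure at the dose given. Compound 1 `Nc1ncc(-c2nc3ccccc3s2)c(N[C@@H]2C[C@H](CO)[C@@H](O)[C@H]2O)n1` gives 149 ng.h/mL. Compound 2 `Cc1nc(NCC2CC2)nc(N[C@@H]2C[C@H](CO)[C@@H](O)[C@H]2O)c1-c1nc2ccccc2s1` gives 1410 ng.h/mL, and compound 3 `Cc1nc(NCCOC(C)C)nc(N[C@@H]2C[C@H](CO)[C@@H](O)[C@H]2O)c1-c1nc2ccccc2s1` gives 426 ng.h/mL. Among these three numbers compound 3 stands second highest: compound 1 sits nearer to it and compound 2 lies further off, with both gaps beyond the scatter. Among the measured compounds shown here, the single step between compounds that differ in one place is a 3.3-fold lower number from compound 2 to compound 3 (0.52 log units; beyond the scatter), in which isopropoxymethyl replaces cyclopropyl on a saturated chain carbon bound to a nitrogen on an aromatic ring.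

Compound 4 `Cc1nc(NCc2ccccn2)nc(N[C@@H]2C[C@H](CO)[C@@H](O)[C@H]2O)c1-c1nc2ccccc2s1` continues from compound 3 by the change (pyridin-2-yl in place of isopropoxymethyl on a saturated chain carbon bound to a nitrogen on an aromatic ring). This sits at the same place that the step from compound 2 to compound 3 altered, so that step is the only one that bears on it, and it was modest. For the measured compounds named here, no measured pair swaps isopropoxymethyl for pyridin-2-yl, so the direction of the coming step cannot be read from the data; only its likely size can. The estimate for compound 4 is 350 ng.h/mL, with a range from 100 ng.h/mL to 1200 ng.h/mL, which would mean an expected step of a 1.2-fold lower number from compound 3 to compound 4 (0.09 log units; within the scatter), close to the scatter.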

Compound 4, area under the concentration-time curve: 1630 ng.h/mL
Compound 4: middle estimate off by 4.7-fold (0.67 log units), on the low side; measured number outside the range, above it.
By their numbers in this assay, from the lowest: compound 1; then compound 3; then compounds 2 and 4 (each within the scatter of the next).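

In this assay, the position that earlier looked sensitive only to a loss now also shows a gain: the swap gives a 3.8-fold higher number from compound 3 to compound 4 (0.58 log units; beyond the scatter), so the drop seen on leaving cyclopropyl for isopropoxymethyl is not a one-way feature of this place. The new pair adds a direct comparison of the two ring-bearing groups, a 1.2-fold higher number from compound 2 to compound 4 (0.06 log units; within the scatter), which means pyridin-2-yl and cyclopropyl cannot be told apart on this read-out, while among compounds 2, 3 and 4 only the group without a ring, in compound 3, stands apart. The group leaving and the group entering have the same count of hydrogen-bond donors and acceptors, so that count does not separate compound 3 from compound 4, and no supporting measurement is available to explain the difference in exposure.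

With only three groups at this place, the link between a ring and higher exposure remains a description of these compounds, not a rule. A plain phenyl group, pyridin-3-yl or a longer chain ending in an amine at the same place would show whether the ring itself, its nitrogen or neither goes with the higher numbers.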